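A few compounds are considered here, and "the series" means these few. Any claim that something is new, unique, unknown or untested is made for them only; others in the source may bear on it.

Measured in an assay on isolated protein for inhibition of Ca2+/calmodulin-dependent protein kinase II (CaM kinase II) (Rattus norvegicus), tested at 30 uM; on this read-out lower numbers stand for less inhibition and higher numbers for more inhibition at the one concentration tested (going by the name of the read-out):
compound 1, `Clc1ncnc2c1ncn2Cc1ccccc1`, gives 7%;
compound 2, `Fc1ccc(Cn2cnc3c(Cl)ncnc32)cc1`, gives 0%;
compound 3, `Cn1c(-c2ccc([S+](C)[O-])cc2)nc2c(Sc3ccccc3)ncnc21`, gives 8%.

Compound 4, `Cn1c(-c2ccc([S+](C)[O-])cc2)nc2c(Sc3ccc(F)cc3)ncnc21`, has not been measured. It differs from compound 3 in one place: fluoro in place of hydrogen on an aromatic carbon. The same change has been made once before among these compounds, from compound 1 to compound 2, where it is fluoro in place of hydrogen on an aromatic carbon, and there it gave a number 7 percentage points lower from compound 1 to compound 2 (within the scatter). The place of the change is described in identical words in both pairs, so it is the same change on a different core; how the core of compound 3 differs from that of compound 1 is not broken down here.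

Because the earlier step was a number 7 percentage points lower from compound 1 to compound 2 (within the scatter), compound 4 is expected to move only by about a number 4 percentage points lower from compound 3 to compound 4 (within the scatter) in this assay. Compound 4 is therefore estimated at 4%, between -8% and 16%.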

Compound 4, a percentage reported as inhibition, at one concentration (the size of the read-out at that concentration, not a potency): 12%
Compound 4: the middle estimate sits 8 percentage points below what was measured, within the range that was stated.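

In this assay, fluoro in place of hydrogen on an aromatic carbon gave a number 4 percentage points higher from compound 3 to compound 4 (within the scatter), and the two cores can be compared directly: the same change on two cores in this assay, a number 7 percentage points lower (within the scatter) from compound 1 to compound 2 and a number 4 percentage points higher (within the scatter) from compound 3 to compound 4, 11 percentage points apart, within the scatter of two such steps. The change therefore has no effect that can be told from the scatter on either core, and the two results are consistent with each other. This does not show that the change carries over with the same size or direction, nor that it has any real effect on this read-out at all.

From the compounds shown here alone, whether an amine or a carboxylic acid in place of the fluoro would give a step beyond the scatter remains open. Also open, going by these compounds, is whether any such step would hold from one core to the other.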